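Carboxy in Place of Methanesulfonamido on the Phenyl Ring

The source may hold more compounds than are shown below. What is called first, only, known or untested is meant among the compounds shown, and "the series" means these compounds.

Three measured compounds share one core and differ only in the ring attached to it. Compound 1 `CCCS(=O)(=O)Nc1ccc(F)c(C(=O)c2n[nH]c3ncc(-c4ccccc4OC)cc23)c1F` carries a 2-methoxyphenyl; in an assay for binding affinity to dual specificity mitogen-activated protein kinase kinase 4 (Homo sapiens), read by KINOMEscan, tested at 100 nM (a lower number here means a stronger effect, a higher number a weaker effect of the compound at the concentration tested), compound 1 gives 1.9%. Compound 2 `CCCS(=O)(=O)Nc1ccc(F)c(C(=O)c2n[nH]c3ncc(-c4ccc(S(=O)(=O)NCC)cc4)cc23)c1F` carries a 4-(ethylsulfamoyl)phenyl, and compound 2 gives 3%. Compound 3 `CCCS(=O)(=O)Nc1ccc(F)c(C(=O)c2n[nH]c3ncc(-c4ccc(NS(C)(=O)=O)cc4)cc23)c1F` carries a 4-(methanesulfonamido)phenyl, and compound 3 gives 0.85%, the lowest of the three numbers shown, although a number 1.1 percentage points lower from compound 1 to compound 3 (within the scatter) and a number 2.2 percentage points lower from compound 2 to compound 3 (within the scatter) both lie within the scatter, as does a number 1.1 percentage points higher from compound 1 to compound 2 (within the scatter).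

Compound 4 `CCCS(=O)(=O)Nc1ccc(F)c(C(=O)c2n[nH]c3ncc(-c4ccc(C(=O)O)cc4)cc23)c1F` has not been measured. It differs from compound 3 in one place: carboxy in place of methanesulfonamido on an aromatic carbon. For the measured compounds named here, the one measured step that exchanges the group on that same aromatic carbon, a number 2.2 percentage points lower from compound 2 to compound 3 (within the scatter), stayed within the scatter, and every exchange among the three measured compounds did the same. A step of no more than the scatter, in no clear direction, is therefore expected, a number 2.2 percentage points higher from compound 3 to compound 4 (within the scatter). Compound 4 is estimated at 3%, with an expected range from 0.5% to 15%.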

Compound 4, a percentage reported as activity, at one concentration (the size of the read-out at that concentration, not a potency): 0.1%
The estimate for compound 4 lay 2.9 percentage points above the measured number; measured number below the stated range.
By their numbers in this assay, from the lowest: compounds 4, 3, 1 and 2 (each within the scatter of the next).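

In this assay, the carboxy, with 3 heavy atoms and no sulfur, takes the place of the methanesulfonamido, with 5 heavy atoms and one sulfur, without a step beyond the scatter (a number 0.8 percentage points lower from compound 3 to compound 4 (within the scatter)). The comparisons with the other two compounds read the same way (a number 2.9 percentage points lower from compound 2 to compound 4 (within the scatter)) and (a number 1.8 percentage points lower from compound 1 to compound 4 (within the scatter)). The earlier compounds shown here showed this only for groups containing sulfur or methoxy, so the range of groups accepted on this ring now includes a carboxy.

Nothing given here accounts for this tolerance. From the compounds shown here alone, whether an amine, a primary amide or a methyl ester on the same aromatic carbon would also stay within the scatter remains open, as does how these compounds would separate at a concentration other than the single one tested.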